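The source may report more compounds than this note shows. Statements on the series, on what has been measured and on what is new or still open speak of the compounds shown alone.

Measured in a functional assay on MDA-MB-231 cells (Homo sapiens) for inhibition, read by sulforhodamine B assay, with a stated time of 72 h; on this read-out higher numbers stand for weaker inhibition of growth and lower numbers for stronger inhibition of growth:
Compound 1 `CN1CCN(C(=O)/C=C/c2ccncc2-c2ccc3ccccc3c2)CC1`: > 10000 nM (a limit of the assay)
Compound 2 `CNC(=O)CCc1ccncc1-c1ccc2ccccc2c1`: 8980 nM

Going by the values given here, compound 2 holds the only actual number so far, since the other result is a limit. Compound 3 `CN(C)C(=O)/C=C/c1ccncc1-c1ccc2ccccc2c1` is not yet measured. It carries 2-(dimethylcarbamoyl)ethenyl in place of 2-(methylcarbamoyl)ethyl on an aromatic carbon, ortho to a large group and opposite the ring nitrogen (2-(dimethylcarbamoyl)ethenyl in place of 2-(methylcarbamoyl)ethyl on an aromatic carbon). Compound 1, which also carries an ethenyl amide, stands at > 10000 nM, a limit. No step beyond the scatter is therefore expected in this assay, and the estimated step is a 1.1-fold higher number from compound 2 to compound 3 (0.05 log units; within the scatter). For compound 3 the expected value is 10000 nM, within an estimated range of 3500 nM to 30000 nM.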

Compound 3, concentration for 50% growth inhibition: 7990 nM
Compound 3: the middle estimate sits 1.3-fold (0.10 log units) above what was measured; low and high end bracket the measured number.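

In this assay, 2-(dimethylcarbamoyl)ethenyl in place of 2-(methylcarbamoyl)ethyl gives a 1.1-fold lower number from compound 2 to compound 3 (0.05 log units; within the scatter), so this change on the aromatic carbon opposite the ring nitrogen leaves the number within the scatter. Dimethylamino in place of 4-methylpiperazin-1-yl on the carbonyl carbon gives an at least 1.2-fold lower number from compound 1 to compound 3 (0.09 log units; that floor lies within the scatter). Compound 1 is a limit of the assay, so that step is only a floor: the limit of > 10000 nM in this assay, at which 1 of the 3 values shown sits.

The change from compound 2 to compound 3 alters both the chain's double bonds and the amide substitution, and these two cannot be read apart here. From the compounds shown here alone, whether a carboxylic acid or a primary amine at this position would move the number remains open.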